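Swapping the oxygen substituent on a shared core

This account rests on a few compounds, and the source may have more. Where it says the series, first, only, none or still open, it means among the compounds named here.

Measured in a functional assay on HL-60 cells (Homo sapiens) for cytotoxicity, read by MTT assay, with a stated time of 24 h; on this read-out higher numbers stand for weaker inhibition and lower numbers for stronger inhibition:
Compound 1 `CC(=O)Oc1c(Br)cc(Br)cc1Oc1ccc(Br)cc1Br`: 29.9 ug/mL
Compound 2 `BrCCCCCOc1c(Br)cc(Br)cc1Oc1ccc(Br)cc1Br`: 25.7 ug/mL
Compound 3 `CC(C)(C)C(=O)C(C#N)Oc1c(Br)cc(Br)cc1Oc1ccc(Br)cc1Br`: 29.2 ug/mL

Compound 3 stands with the other two, with a 1.0-fold lower number from compound 1 to compound 3 (0.01 log units; within the scatter) and a 1.1-fold higher number from compound 2 to compound 3 (0.06 log units; within the scatter), so nothing separates it from either. The third step, a 1.2-fold lower number from compound 1 to compound 2 (0.07 log units; within the scatter), is of the same small size.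

Next comes compound 4 `OCCOc1c(Br)cc(Br)cc1Oc1ccc(Br)cc1Br`, with 2-hydroxyethyl in place of cyano((tert-butyl)carbonyl)methyl on an oxygen on an aromatic ring. All three measured steps bear on this change, since each exchanges the group at that same place, and none leaves the scatter in this assay. Among the compounds with values here, none of the measured compounds carries 2-hydroxyethyl, so the expectation is an extrapolation from those steps. No step beyond the scatter is expected, in either direction. The expected step is a 1.1-fold lower number from compound 3 to compound 4 (0.03 log units; within the scatter). For compound 4 the estimated value is 27 ug/mL, with an expected range of 15 ug/mL to 46 ug/mL.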

Compound 4, half-maximal inhibitory concentration: 28.2 ug/mL
For compound 4 the middle estimate is 1.0-fold (0.02 log units) below the measured one; the range from low to high includes it.
By their numbers in this assay, from the lowest: compounds 2, 4, 3 and 1 (each within the scatter of the next).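

In this assay, going from cyano((tert-butyl)carbonyl)methyl, with 9 heavy atoms and 0 hydrogen-bond donors, to 2-hydroxyethyl, with 3 heavy atoms and 1 hydrogen-bond donor, stays within the scatter (a 1.0-fold lower number from compound 3 to compound 4 (0.02 log units; within the scatter)), and the comparisons with the other two groups on an oxygen on an aromatic ring do the same (a 1.1-fold higher number from compound 2 to compound 4 (0.04 log units; within the scatter); a 1.1-fold lower number from compound 1 to compound 4 (0.03 log units; within the scatter)). Across the four compounds, then, neither this smaller group nor its hydrogen-bond donor separates compound 4 from the others, so the position remains without a measured preference. No measurement at hand offers an explanation for this flat result.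

As far as these compounds go, whether an amine or a carboxylic acid on this oxygen would leave the scatter remains open. So does whether a chain longer than 5-bromopentyl would do so.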